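Amide Side Chain Change on a Quinazoline Core

A few compounds are considered here, and "the series" means these few. Any claim that something is new, unique, unknown or untested is made for them only; others in the source may bear on it.

Compound 1 `COc1cc2ncnc(N3CCc4ccccc43)c2cc1NC(=O)C=C(C)C`: 6270 nM
Compound 2 `CC(C)=CC(=O)Nc1cc2c(N3CCc4ccccc43)ncnc2cc1O[C@@H]1CCOC1`: 3670 nM
Compound 3 `CCC/C=C/C(=O)Nc1cc2c(N3CCCc4ccccc43)ncnc2cc1O[C@@H]1CCOC1`: 7320 nM

In a functional assay on A549 cells (Homo sapiens) for antiproliferative activity, read by MTT assay, with a stated time of 72 h (a lower number here means a stronger inhibitor, a higher number a weaker inhibitor), compound 1 stands second highest of the three numbers, with compound 3 nearest and compound 2 furthest, both within the scatter. Going by the values given here, the only single-point step, a 1.7-fold lower number from compound 1 to compound 2 (0.23 log units; within the scatter), lies on the ether oxygen and within the scatter. Compound 4 `COc1cc2ncnc(N3CCc4ccccc43)c2cc1NC(=O)/C=C/CN1CCCC1` differs from compound 1 on the carbonyl carbon: 3-(pyrrolidin-1-yl)prop-1-en-1-yl in place of 2-methylprop-1-en-1-yl on a carbonyl carbon. Among the compounds with values here, no measured step touches this carbonyl substituent, and compounds 2 and 3 differ in two places, so their values show only that both sit close to compound 1. Compound 4 is therefore expected to show no step beyond the scatter, a 1.3-fold lower number from compound 1 to compound 4 (0.10 log units; within the scatter), with an estimate of 5000 nM and a range from 1500 nM to 15000 nM.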

Compound 4, half-maximal inhibitory concentration: 1210 nM
Compound 4: middle estimate off by 4.1-fold (0.62 log units), on the high side; the whole stated range lies above it.
By their numbers in this assay, from the lowest: compound 4; then compounds 2, 1 and 3 (each within the scatter of the next).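

Unlike the change on the ether oxygen, the change on the carbonyl carbon moves the number in this assay: 3-(pyrrolidin-1-yl)prop-1-en-1-yl in place of 2-methylprop-1-en-1-yl gives a 5.2-fold lower number from compound 1 to compound 4 (0.71 log units; beyond the scatter) and so is the only step shown that lies beyond the scatter. The entering group adds a nitrogen and a five-membered ring at once, and this single step cannot separate the two. Nothing measured here accounts for the step.

Going by these compounds, whether the ring is needed stays open, as a dimethylamino group, piperidine or morpholine in place of the pyrrolidine would show. Also open, on these data alone, is whether this side chain behaves alike with the oxolan-3-yl ether of compound 2.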